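The compounds below may be only part of what the source reports. "The series", "measured", "known", "first", "only" and "open" are said of these compounds alone.

Compounds 1, 2 and 3 share one core and differ only in their outer groups: compound 1 `CNC(=O)c1ccc(NCc2cncn2Cc2ccc(-c3ccccc3)cc2N)cc1-c1ccccc1`, compound 2 `COC(=O)c1ccc(NCc2cncn2Cc2ccccc2)cc1-c1ccccc1` and compound 3 `c1ccc(Cn2cncc2CNc2cccc(-c3ccccc3)c2)cc1`. In a toxicity assay on NIH3T3 cells (Mus musculus) for cytotoxicity, read by resazurin assay (on this read-out higher numbers stand for an effect only at larger amounts of compound and lower numbers for an effect already at smaller amounts), compound 1 gives only a limit of the assay, > 1000 nM. Compound 2 likewise reaches only a limit in this assay, > 1000 nM. Compound 3 too gives only a limit, > 750 nM. Compound 2 thus stands at a limit, and the two further values shown are limits as well, so the step that the two limits leave unreadable from compound 2 to compound 3, hydrogen in place of methoxycarbonyl on an aromatic carbon, cannot be read. Compound 4 `COC(=O)c1ccc(NCc2cncn2Cc2cccc(Cl)c2)cc1-c1ccccc1` is not yet measured; it differs from compound 2 by chloro in place of hydrogen on an aromatic carbon, placed on an aromatic carbon of a six-membered aromatic ring of carbon only. Going by the values given here, no measured step bears on this change, and every value shown sits at a limit, the limit of > 1000 nM in this assay, at which 2 of the 3 values shown sit, and (the limit of > 750 nM in this assay, at which 1 of the 3 values shown sits). Among the compounds with values here, compound 4 is therefore expected to remain at the limit, and a step that the limit leaves unreadable from compound 2 to compound 4 is expected to be no step readable beyond the scatter. The estimate for compound 4 in this assay is 3000 nM, within 800 nM to 20000 nM.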

Compound 4, half-maximal effective concentration: > 10000 nM
Compound 4: only a limit was reported; the forecaster's own chance of this, stated with the estimate: 85%; middle value at least 3.3-fold (0.52 log units) from the limit.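

In this assay compound 4 gives only a limit, > 10000 nM. Compound 2 also stands at a limit, so no step can be read between compound 2 and compound 4. The compounds shown leave open at what concentration any of them affects these cells, and whether chloro in place of hydrogen changes it.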